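Furan to Thiophene in a Thiosemicarbazone Series

This account rests on a few compounds, and the source may have more. Where it says the series, first, only, none or still open, it means among the compounds named here.

In a functional assay on K562 cells (Homo sapiens) for inhibition, read by sulforhodamine B assay, with a stated time of 48 h (a lower number here means a stronger inhibitor of growth, a higher number a weaker inhibitor of growth), compound 1 `CC1=CC[C@H](C(C)(C)NC(=S)NN)CC1` returns only a limit, > 100000 nM (the limit of > 100000 nM in this assay, at which 1 of the 2 values shown sits). In this assay, among the measured compounds shown here, compound 2 `CC1=CC[C@H](C(C)(C)NC(=S)N/N=C/c2ccco2)CC1` gives 100 nM, the sole number among the two values shown. For the measured compounds named here, the one measured step, an at least 1000-fold lower number from compound 1 to compound 2 (3.00 log units; beyond the scatter), adds the entire furan-bearing hydrazone group, so it touches the present change only loosely. Compound 3 `CC1=CC[C@H](C(C)(C)NC(=S)N/N=C/c2cccs2)CC1` differs from compound 2 by thiophen-2-yl in place of furan-2-yl on a carbon with a double bond to nitrogen. Lacking any measured swap of one five-membered ring for another, he expects a step of no change at the digits printed from compound 2 to compound 3 (within the scatter), nothing beyond the scatter. Compound 3 is therefore estimated at 100 nM, within 30 nM to 300 nM.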

Compound 3, concentration for 50% growth inhibition: 17600 nM
For compound 3 the middle estimate is 180-fold (2.25 log units) below the measured one; measured number outside the range, above it.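

In this assay, the ring on this carbon with a double bond to nitrogen proves far from interchangeable: thiophen-2-yl in place of furan-2-yl gives a 180-fold higher number from compound 2 to compound 3 (2.25 log units; beyond the scatter), although both groups share the same counts of heavy atoms, donors and acceptors. The thiophene-bearing group still gives an at least 5.6-fold lower number from compound 1 to compound 3 (0.75 log units; beyond the scatter), so adding it retains a measurable gain. Compound 1 stands only as a limit, not a number: the limit of > 100000 nM in this assay, at which 1 of the 3 values shown sits.

Going by these compounds, whether a phenyl or pyridine ring here would resemble compound 2 or compound 3 remains open. The cause of the step also remains unknown.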